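This account rests on a few compounds, and the source may have more. Where it says the series, first, only, none or still open, it means among the compounds named here.

Working notes on four compounds sharing one core, read in a functional assay on HCT-15 cells (Homo sapiens) for cytotoxicity, read by sulforhodamine B assay, with a stated time of 48 h; on this read-out lower numbers stand for higher toxicity in this test and higher numbers for lower toxicity in this test. Compound 1 `ClCc1ccccc1Cn1cnc2c(Cl)nc(Cl)nc21` gives 4780 nM in this assay. Compound 2 `ClCc1cccc(Cn2cnc3c(Cl)nc(Cl)nc32)c1` is built from the same atoms joined differently; the difference between the two cores is not broken down here. In this assay compound 2 returns only a limit, > 100000 nM. Compound 3 `Nc1nc(Cl)c2ncn(Cc3ccccc3CCl)c2n1` differs from compound 1 by amino in place of chloro on an aromatic carbon. For compound 3 this assay again returns a limit, > 100000 nM. The measured step is an at least 20-fold higher number from compound 1 to compound 3 (1.32 log units; beyond the scatter), so putting amino in place of chloro on the aromatic carbon leaves compound 3 at a limit where compound 1 had a number. Two of the three values shown sit at the limit of > 100000 nM in this assay, at which 2 of the 3 values shown sit.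

Compound 4 `Nc1nc(Cl)c2ncn(Cc3cccc(CCl)c3)c2n1` is the member not yet measured. It differs from compound 2 by amino in place of chloro on an aromatic carbon, the same change as that between compound 1 and compound 3, and the place of the change is described in the same words for both pairs. Among the compounds shown this change occurs two times in all. Within the data shown here, the step from compound 2 to compound 4 is expected to be a step that the limit leaves unreadable from compound 2 to compound 4, which is to say no resolvable step, because the limit of > 100000 nM in this assay, at which 2 of the 3 values shown sit, already holds compound 2 and the one measured instance of this change gave an at least 20-fold higher number from compound 1 to compound 3 (1.32 log units; beyond the scatter), toward lower toxicity, so a limit is expected again. For compound 4 the estimated value in this assay is 200000 nM, with an expected range from 100000 nM to 1000000 nM.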

Compound 4, concentration lethal to 50% of the cells: 33100 nM
Estimate against measurement, compound 4: 6.0-fold (0.78 log units) above; measured number outside the range, below it.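

Amino in place of chloro on the aromatic carbon gives an at least 3.0-fold lower number from compound 2 to compound 4 (0.48 log units; beyond the scatter) in this assay, which on this read-out means higher toxicity in this test. Set beside the earlier step, the same change does not carry over from one core to the other as a fixed shift, and its direction is not kept either: the same change on two cores in this assay, an at least 20-fold higher number (1.32 log units; beyond the scatter) from compound 1 to compound 3 and an at least 3.0-fold lower number (0.48 log units; beyond the scatter) from compound 2 to compound 4, at least 63-fold (1.80 log units) apart, beyond the scatter of two such steps This does not give the true size of either step or a reason for the difference between them, and two pairs on two cores set no rule for any further core; both steps are bounds and not exact sizes, with compound 2 and compound 3 each standing at a limit: the limit of > 100000 nM in this assay, at which 2 of the 4 values shown sit.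

Open, on these data alone, is whether another group on the same aromatic carbon, such as methylamino, methoxy or hydroxyl, would follow the step to compound 3 or the step to compound 4. Also open, as far as these compounds go, is how much of the difference between the two cores depends on the chloromethyl group itself, a question that a methyl or hydroxymethyl group in its place on both cores could address.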